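Swapping the Tetrazole Side Chain for a Thiadiazole

This account rests on a few compounds, and the source may have more. Where it says the series, first, only, none or still open, it means among the compounds named here.

compound 1, `CO[C@H]1C(=O)N2C(C(=O)C(C)(C)C)=C(CSc3nnnn3C)C(Sc3nnnn3C)S(=O)(=O)[C@H]12`: 24 h
compound 2, `CO[C@H]1C(=O)N2C(C(=O)c3ccccc3)=C(CSc3nnnn3C)CS(=O)(=O)[C@H]12`: 8.6 h
compound 3, `CO[C@H]1C(=O)N2C(C(=O)C(C)(C)C)=C(CSc3nnnn3C)CS(=O)(=O)[C@H]12`: 24 h

In a physicochemical assay for pharmacokinetics, at 37 degrees C (on this read-out higher numbers stand for a longer-lived compound and lower numbers for a shorter-lived compound), compound 3 gives 24 h. It is level with compound 1 at the digits shown, and these two share the highest number of the three; compound 2 sits furthest away, with a 2.8-fold higher number from compound 2 to compound 3 (0.45 log units; beyond the scatter). The other step, no change at the digits printed from compound 1 to compound 3 (within the scatter), shows that losing the (1-methyl-1H-tetrazol-5-yl)sulfanyl group on the saturated ring carbon leaves the result unmoved.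

Compound 4, `CO[C@H]1C(=O)N2C(C(=O)C(C)(C)C)=C(CSc3nnc(C)s3)CS(=O)(=O)[C@H]12`, carries 5-methyl-1,3,4-thiadiazol-2-yl in place of 1-methyl-1H-tetrazol-5-yl on a sulfur. Neither measured step touches this place: one concerns the group on the carbonyl carbon, the other a substituent on a saturated ring carbon, and the side-chain sulfur is altered in neither. The data therefore hold no direct guide for this exchange, and an expectation can rest only on the fact that compound 3 and compound 1 agree while the acyl change of a 2.8-fold higher number from compound 2 to compound 3 (0.45 log units; beyond the scatter) was modest.

Compound 4 is thus expected to stay close to compound 3, with an estimated step of no change at the digits printed from compound 3 to compound 4 (within the scatter), which means no change beyond the scatter. The estimate for compound 4 in this assay is 24 h, within a range of 12 h to 45 h.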

Compound 4, half-life: 37 h
Compound 4: the middle estimate sits 1.5-fold (0.19 log units) below what was measured, and the stated range covers the measured number.
By their numbers in this assay, from the lowest: compound 2; then compounds 1, 3 and 4 (each within the scatter of the next).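

In this assay, among the compounds shown here, the step to 5-methyl-1,3,4-thiadiazol-2-yl in place of 1-methyl-1H-tetrazol-5-yl on a sulfur reads as a 1.5-fold higher number from compound 3 to compound 4 (0.19 log units; within the scatter) and gives the only reading at this place, where the earlier compounds offered none. It shows that, with tert-butyl on the carbonyl carbon, one five-membered aromatic ring can stand in for the other on this sulfur without a difference beyond the scatter, even though the two rings differ in their hetero atoms. This place thus resembles the saturated ring carbon, whose step reads as no change at the digits printed from compound 1 to compound 3 (within the scatter) and not the carbonyl carbon, whose step reads as a 2.8-fold higher number from compound 2 to compound 3 (0.45 log units; beyond the scatter) and is the only one of the three beyond the scatter. Nothing given here accounts for this outcome.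

The compounds shown leave open whether the same ring exchange would read alike with phenyl on the carbonyl carbon, as in compound 2, or with the (1-methyl-1H-tetrazol-5-yl)sulfanyl group on the saturated ring carbon, as in compound 1. They also leave open how this sulfur would respond to a ring carrying a carboxylic acid or an amine, or to a plain ethyl chain in place of a ring.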